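From 5-hydroxypentyl to hydroxy on compound 1

The source may hold more compounds than are shown below. What is called first, only, known or untested is meant among the compounds shown, and "the series" means these compounds.

Among the measured compounds shown here, in a functional assay on SW-620 cells (Homo sapiens) (on this read-out higher numbers stand for weaker inhibition and lower numbers for stronger inhibition), compound 1 `COc1cc(NC(C)CCCNC(=O)NCCCCCO)c2ncccc2c1` gives 200 nM, the lowest number so far. Compound 2 `COc1cc(NC(C)CCCNC(=O)NOCc2ccccc2)c2ncccc2c1`, with benzyloxy in place of 5-hydroxypentyl on an amide-type nitrogen, gives 20000 nM. Compound 3 `COc1cc(NC(C)CCCNC(=O)NC(CO)(CO)CO)c2ncccc2c1`, with 2-hydroxy-1,1-bis(hydroxymethyl)ethyl there, reads > 100000 nM, which is a limit of the assay.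

Compound 4 `COc1cc(NC(C)CCCNC(=O)NO)c2ncccc2c1` carries hydroxy in place of 5-hydroxypentyl on that nitrogen: hydroxy in place of 5-hydroxypentyl on an amide-type nitrogen. The two measured replacements of this chain gave a 100-fold higher number from compound 1 to compound 2 (2.00 log units; beyond the scatter) and an at least 500-fold higher number from compound 1 to compound 3 (2.69 log units; beyond the scatter), so a large step towards weaker inhibition is expected here too. The estimated change is a 50-fold higher number from compound 1 to compound 4 (1.70 log units; beyond the scatter). Compound 4 is expected at about 10000 nM, within a range of 1500 nM to 60000 nM.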

Compound 4, half-maximal inhibitory concentration: 35000 nM
For compound 4 the middle estimate is 3.5-fold (0.54 log units) below the measured one, and the stated range covers the measured number.
By their numbers in this assay, from the lowest: compound 1; then compounds 2 and 4 (each within the scatter of the next). At a limit, above all of these: compound 3.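

Hydroxy on the amide-type nitrogen gives a 180-fold higher number from compound 1 to compound 4 (2.24 log units; beyond the scatter), so the chain of compound 1 cannot be cut back to its hydroxy alone without a large loss. Hydrogen in place of benzyl on the oxygen makes no readable difference, with a 1.8-fold higher number from compound 2 to compound 4 (0.24 log units; within the scatter). The step of an at least 2.8-fold lower number from compound 3 to compound 4 (0.45 log units; beyond the scatter) is only a bound, resting on a limit: the limit of > 100000 nM in this assay, at which 1 of the 4 values shown sits.

Still open, on these data alone, is whether the chain's length or its end hydroxy carries the effect. A plain pentyl, a shorter hydroxypropyl or a pentyl chain ending in an amine would separate the two.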